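Branched Chain in Place of an Aromatic Ring

The source may hold more compounds than are shown below. What is called first, only, known or untested is meant among the compounds shown, and "the series" means these compounds.

Compound 1 `COc1ccccc1Cc1cnc(CCc2ccc(-c3ccccc3C(=O)O)cc2)[nH]1`: 163 nM
Compound 2 `CCCCc1cnc(C(CCC)Cc2ccc(-c3ccccc3C(=O)O)cc2)[nH]1`: 165 nM

In an in vitro functional assay on cells for agonist activity at Bombesin receptor subtype-3 (Mus musculus), read by luminescence and calcium flux (on this read-out higher numbers stand for an effect only at larger amounts of compound and lower numbers for an effect already at smaller amounts), compound 1 gives 163 nM, the lowest of the two numbers shown, and compound 2 gives 165 nM, which lies within the scatter of that. Compound 3 `CCC(C)(CC)Cc1cnc(CCc2ccc(-c3ccccc3C(=O)O)cc2)[nH]1` has not been measured yet. It differs from compound 1 by 1-ethyl-1-methylpropyl in place of 2-methoxyphenyl on a saturated chain carbon bound to an aromatic carbon. Compound 2 shows that a saturated chain in this part of the shared core is compatible with a similar number, so no step beyond the scatter is expected. The expected step of a 1.2-fold higher number from compound 1 to compound 3 (0.09 log units; within the scatter) is none beyond the scatter. Compound 3 is estimated at 200 nM, between 80 nM and 500 nM.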

Compound 3, half-maximal effective concentration: 30 nM
The estimate for compound 3 lay 6.7-fold (0.82 log units) above the measured number; measured number outside the range, below it.
By their numbers in this assay, from the lowest: compound 3; then compounds 1 and 2 (each within the scatter of the next).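

In this assay, the change to 1-ethyl-1-methylpropyl in place of 2-methoxyphenyl gives a 5.4-fold lower number from compound 1 to compound 3 (0.74 log units; beyond the scatter), a step beyond the scatter. At this position, then, an aromatic ring and a hydrogen-bond acceptor are not required for a low number, since compound 3 has neither here and still gives the lower number. The data offered here give no explanation for this step.

On these data alone, whether the branching itself matters stays open. A straight hexyl chain or a cyclohexyl ring in this place would help to answer that.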